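The source may report more compounds than this note shows. Statements on the series, on what has been measured and on what is new or still open speak of the compounds shown alone.

Of the compounds shown here, two sharing one core have been measured in a physicochemical assay, with a stated time of 6 min; a higher number here means a weaker inhibitor, a lower number a stronger inhibitor. Compound 1 (`O=C(Nc1ccc(F)cc1)Nc1nc(-c2cc3ccccc3o2)cs1`) gives 1130 nM. Compound 2 (`O=C(Nc1ccc([N+](=O)[O-])cc1)Nc1nc(-c2cc3cc(Br)ccc3o2)cs1`) returns only a limit, > 200000 nM, so no number stands for it. In this series that boundary is the limit of > 200000 nM in this assay, at which 1 of the 2 values shown sits. Compound 1 and compound 2 differ in more than one place, so their two values are taken only as they stand: a measured number for compound 1 and a limit for compound 2.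

Compound 3 (`COc1cccc(NC(=O)Nc2nc(-c3cc4cc(Br)ccc4o3)cs2)c1`) is yet to be measured in this assay. Its change from compound 2 is 3-methoxyphenyl in place of 4-nitrophenyl on an amide-type nitrogen. Going by the values given here, no step between compounds differing in one place has been measured, so the size of the step can only be guessed. Compound 2 stands at a limit, and any number obtained for compound 3 would lie on the stronger side of it. A step toward a stronger inhibitor is therefore expected, an at least 10-fold lower number from compound 2 to compound 3 (1.00 log units; beyond the scatter). Compound 3 is estimated at 20000 nM, between 1500 nM and 200000 nM, with a fair chance that only a limit is returned.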

Compound 3, half-maximal inhibitory concentration: > 200000 nM
Compound 3: a limit, no number; the forecaster's own chance of this, stated with the estimate: 35%; at least 10-fold (1.00 log units) between middle value and limit.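

Compound 3 in this assay returns the limit > 200000 nM and no number. Compound 2 also stands at a limit, and no step can be read between compound 2 and compound 3. Which of 3-methoxyphenyl and 4-nitrophenyl on the amide-type nitrogen gives the stronger inhibitor stays open. The boundary these two compounds share is this: the limit of > 200000 nM in this assay, at which 2 of the 3 values shown sit.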